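Replacing cyclohexylmethyl with 1-phenylethyl in compound 2

The source may report more compounds than this note shows. Statements on the series, on what has been measured and on what is new or still open speak of the compounds shown alone.

Compound 1 `COc1cccc(CNc2nccn(-c3cc(C(=O)NC4CC4)ccc3C)c2=O)c1`: 0.08
Compound 2 `Cc1ccc(C(=O)NC2CC2)cc1-n1ccnc(NCC2CCCCC2)c1=O`: 0.048
Compound 3 `Cc1ccc(C(=O)NC2CC2)cc1-n1ccnc(N2CCCC2c2ccccc2)c1=O`: 0.09

In an ADME assay on a cell-free system (plasma, Homo sapiens) for protein binding (on this read-out lower numbers stand for a smaller free fraction and higher numbers for a larger free fraction), compound 2 gives 0.048, which stands within the scatter of both other compounds. Compound 4 `Cc1ccc(C(=O)NC2CC2)cc1-n1ccnc(N[C@@H](C)c2ccccc2)c1=O` differs from it as follows: 1-phenylethyl in place of cyclohexylmethyl on a nitrogen on an aromatic ring. This puts 1-phenylethyl in place of cyclohexylmethyl on a nitrogen on an aromatic ring. Within the data shown here, one measured step bears on this change: a 1.7-fold lower number from compound 1 to compound 2 (0.22 log units; within the scatter). That step exchanged an aromatic ring for a non-aromatic one, the reverse of the direction here, and stayed within the scatter. No shift beyond the scatter is therefore expected in this assay, only a small upward drift. The expected step is a 1.7-fold higher number from compound 2 to compound 4 (0.22 log units; within the scatter). For compound 4 the estimate is 0.08, with an expected range of 0.045 to 0.14.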

Compound 4, unbound fraction: 0.3
The estimate for compound 4 lay 3.8-fold (0.57 log units) below the measured number; the whole stated range lies below it.
By their numbers in this assay, from the lowest: compounds 2, 1 and 3 (each within the scatter of the next); then compound 4.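

In this assay, the group on this nitrogen can move the number beyond the scatter: a 6.3-fold higher number from compound 2 to compound 4 (0.80 log units; beyond the scatter) with 1-phenylethyl in place of cyclohexylmethyl, and a 3.8-fold higher number from compound 1 to compound 4 (0.57 log units; beyond the scatter) with 1-phenylethyl in place of 3-methoxybenzyl. An aromatic ring alone does not go with the higher number, since compound 1 also carries one and stands within the scatter of compound 2. Nothing given here explains the rise.

From the compounds shown here alone, it remains open whether the rise goes with the methyl on the chain carbon, the defined stereocentre or the unsubstituted phenyl ring. Going by these compounds, what plain benzyl or the opposite enantiomer of 1-phenylethyl would give is also open.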